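The compounds below may be only part of what the source reports. "The series", "measured", "known", "first", "only" and "open" are said of these compounds alone.

Compound 3 `O=C(NC1CCCCC1)Oc1cccc(-c2cc(C(=O)O)nn2-c2ccccc2)c1` carries a carboxy group on its five-membered ring and, in an assay on isolated protein for inhibition of Fatty-acid amide hydrolase 1 (Homo sapiens), read by fluorescence, with a stated time of 30 min (a higher number here means a weaker inhibitor, a lower number a stronger inhibitor), compound 3 gives 2270 nM, the highest of the three numbers measured. Its two companions keep the same core but bear an amide at that position: compound 1 `CC(C)NC(=O)c1cc(-c2cccc(OC(=O)NC3CCCCC3)c2)n(-c2ccccc2)n1` gives 232 nM in this assay, and compound 2 `CCN(CC)C(=O)c1cc(-c2cccc(OC(=O)NC3CCCCC3)c2)n(-c2ccccc2)n1` gives 448 nM. The step of a 1.9-fold higher number from compound 1 to compound 2 (0.29 log units; within the scatter) lies within the scatter, whereas a 9.8-fold higher number from compound 1 to compound 3 (0.99 log units; beyond the scatter) and a 5.1-fold higher number from compound 2 to compound 3 (0.70 log units; beyond the scatter) both show that the carboxy group sits at the weak end of this small set.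

Compound 4 `O=C(NC1CCCCC1)Oc1cccc(-c2cc(CO)nn2-c2ccccc2)c1` takes the step (hydroxymethyl in place of carboxy on an aromatic carbon). Going by the values given here, no measured step here exchanges a carboxy for a hydroxymethyl, so the two steps that bear on it are only those from the amides to the acid. Since compound 3 shows the weakest number, and since the neutral amides of compound 1 (232 nM) and compound 2 (448 nM) sit lower, a modest improvement on leaving the carboxy group is expected, the step of a 2.8-fold lower number from compound 3 to compound 4 (0.45 log units; beyond the scatter) being the estimated size. Compound 4 is therefore expected to give about 800 nM in this assay, within a range of 250 nM to 2600 nM.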

Compound 4, half-maximal inhibitory concentration: 462 nM
Estimate against measurement, compound 4: 1.7-fold (0.24 log units) above; the range from low to high includes it.
By their numbers in this assay, from the lowest: compounds 1, 2 and 4 (each within the scatter of the next); then compound 3.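

Hydroxymethyl in place of carboxy gives a 4.9-fold lower number from compound 3 to compound 4 (0.69 log units; beyond the scatter) in this assay, so moving away from the weak end of this set at this position does not depend on an amide. Compound 4 also sits level with both amides, with a 1.0-fold higher number from compound 2 to compound 4 (0.01 log units; within the scatter) and a 2.0-fold higher number from compound 1 to compound 4 (0.30 log units; within the scatter), so among these compounds neither a carbonyl at this position nor an amide nitrogen is needed to reach their level. Nothing given here accounts for the change from carboxy to hydroxymethyl.

The compounds shown leave open whether the hydroxyl of the hydroxymethyl group matters, which a plain methyl or a methoxymethyl group would test. They also leave open how a longer chain such as hydroxyethyl, or an aminomethyl group, would read at this position.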